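Benzyl in Place of Hydroxy on a Sulfonamide Piperidine Core

This account rests on a few compounds, and the source may have more. Where it says the series, first, only, none or still open, it means among the compounds named here.

Measured so far in an ADME assay on HCT-116 cells (Homo sapiens) for cytotoxicity, read by CellTiter-Glo, with a stated time of 72 h; on this read-out lower numbers stand for stronger inhibition and higher numbers for weaker inhibition:
Compound 1 `Cc1cc(C)c(S(=O)(=O)N2CCC(N3CCC(O)CC3)CC2)c(C)c1` gives > 5000 nM, a limit of the assay.
Compound 2 `Cc1cc(C)c(S(=O)(=O)N2CCC(C(=O)N3CCC(C)CC3)CC2)c(C)c1` gives > 5000 nM, a limit of the assay.
Compound 3 `Cc1ccc(C2CCN(S(=O)(=O)c3c(C)cc(C)cc3C)CC2)cc1` gives > 5000 nM, a limit of the assay.

Compound 1 stands at the limit (the limit of > 5000 nM in this assay, at which 3 of the 3 values shown sit), where every value shown sits, so its exact position among the three cannot be read. The three steps among them, a step that the two limits leave unreadable from compound 1 to compound 2, a step that the two limits leave unreadable from compound 1 to compound 3 and a step that the two limits leave unreadable from compound 2 to compound 3, all stay unreadable for the same reason: both ends of each step are limits rather than numbers.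

Compound 4 `Cc1cc(C)c(S(=O)(=O)N2CCC(N3CCC(Cc4ccccc4)CC3)CC2)c(C)c1` differs from compound 1 in one place: benzyl in place of hydroxy on a saturated ring carbon. Within the data shown here, no measured step here replaces a hydroxy with a benzyl, so none bears directly on this change. Among the measured compounds shown here, the only guide is that compound 1 and its two measured relatives all sit at the limit, which points to a compound 4 that is expected to stay near the same limit, with a step that the limit leaves unreadable from compound 1 to compound 4 giving no step beyond the scatter in either direction. Compound 4 is therefore estimated at 8000 nM, within a range from 2500 nM to 25000 nM.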

Compound 4, half-maximal inhibitory concentration: > 5000 nM
Compound 4: only a limit was reported (the forecaster's own chance of this, stated with the estimate: 70%); the middle value is on the limit's open side.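

Compound 1 and compound 4 both sit at the same limit in this assay, so no new step can be read between them: the limit of > 5000 nM in this assay, at which 4 of the 4 values shown sit.

The compounds shown leave open whether any change on the shared core gives a true number rather than a limit in this assay at all.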